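The source may report more compounds than this note shows. Statements on the series, on what has been measured and on what is new or still open speak of the compounds shown alone.

Measured so far:
compound 1, `CCCCNc1nc(NCc2ccccc2)c2ccccc2n1`, <= 10000 nM
compound 2, `c1ccc(CNc2nc(Nc3ccccc3)nc3ccccc23)cc1`, <= 5000 nM
compound 3, `CCCCNc1nc(NCc2ccccc2)nc2ccccc12`, <= 10000 nM

All three compounds were tested in a physicochemical assay for solubility, at pH 7.4; a higher number here means a more soluble compound, a lower number a less soluble compound. In this assay compound 1 gives <= 10000 nM, which is a limit of the assay and not a number. Compound 2 gives <= 5000 nM, also a limit. Compound 3 gives <= 10000 nM, again a limit. Because the limit of <= 10000 nM in this assay, at which 2 of the 3 values shown sit, and the limit of <= 5000 nM in this assay, at which 1 of the 3 values shown sits, are limits, the step that the two limits leave unreadable from compound 1 to compound 2 cannot be sized; the change that produced it is phenyl in place of butyl on a nitrogen on an aromatic ring.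

Compound 4, `c1ccc(CNc2nc(Nc3ccccc3)c3ccccc3n2)cc1`, has not yet been measured. For the measured compounds named here, it is made from compound 3 by phenyl in place of butyl on a nitrogen on an aromatic ring, the same kind of change as the one from compound 1 to compound 2, with the place lines reading the same word for word. The difference between the cores of compound 3 and compound 1 is not broken down here.

What can be said about compound 4 rests on the three limits alone. The step from compound 1 to compound 2 was not readable, and compound 3 itself sits at a limit, so the step to compound 4 is expected to be a step that the limit leaves unreadable from compound 3 to compound 4, with no direction that the data can support. Compound 4 is therefore estimated at 3000 nM in this assay, somewhere between 300 nM and 10000 nM, and it is likely that the assay again reports only a limit.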

Compound 4, solubility: <= 5000 nM
Compound 4: a limit, no number (the forecaster's own chance of this, stated with the estimate: 85%); the middle value does not contradict the limit.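

In this assay compound 4 gives <= 5000 nM, which is a limit of the assay and not a number. Compound 3 gives <= 10000 nM, also a limit. With only these two limits, the step between compound 3 and compound 4 cannot be read. The compounds shown leave open the actual solubility of all four, and whether phenyl in place of butyl on this nitrogen makes any difference to it.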